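The compounds below may be only part of what the source reports. "The series", "measured", "known", "first", "only" and "open" are said of these compounds alone.

Measured compounds in an assay for inhibition of leukotriene C4 synthase (Homo sapiens), read by LC-MS, with stated times of 15 min and 30 min; on this read-out higher numbers stand for weaker inhibition and lower numbers for stronger inhibition:
compound 1 `COc1cc(N(CC2CC2)c2ccc(Cl)c(Cl)c2)cnc1C(=O)[C@H]1C[C@@H]1C(=O)O` gives 4.94 nM;
compound 2 `COc1cc(N(CC2CC2)c2ccccc2)cnc1C(=O)[C@H]1C[C@@H]1C(=O)O` gives 158 nM;
compound 3 `COc1nc(C(=O)[C@@H]2C[C@H]2C(=O)O)ncc1N(CC1CC1)c1ccc(Cl)c2ccccc12` gives 15.5 nM.

Compound 2 stands highest of the three numbers in this assay; compound 3 is nearest, compound 1 furthest. The unmeasured compound 4 `COc1cc(N(CC2CC2)c2cc(Cl)c(F)cc2F)cnc1C(=O)[C@H]1C[C@@H]1C(=O)O` differs from compound 2 by 5-chloro-2,4-difluorophenyl in place of phenyl on a nitrogen on an aromatic ring. Within the data shown here, the one measured step that bears on this change is a 32-fold higher number from compound 1 to compound 2 (1.50 log units; beyond the scatter), where the phenyl without halogens gave the much higher number. A halogenated phenyl entering in place of the plain phenyl is therefore expected to lower the number substantially, though the new pattern of halogens is not the one measured, so the size is uncertain. Compound 4 is expected at 12 nM in this assay, range 4 nM to 40 nM, an expected step of a 13-fold lower number from compound 2 to compound 4 (1.12 log units; beyond the scatter).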

Compound 4, half-maximal inhibitory concentration in the leukotriene C4 synthase assay: 1.97 nM
Beside the measured number, compound 4's estimate is 6.1-fold (0.78 log units) above it; the whole stated range lies above it.
By their numbers in the leukotriene C4 synthase assay, from the lowest: compound 4; then compound 1; then compound 3; then compound 2.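

In the leukotriene C4 synthase assay the 5-chloro-2,4-difluorophenyl group on this nitrogen gives an 80-fold lower number from compound 2 to compound 4 (1.90 log units; beyond the scatter) and, set against the 3,4-dichlorophenyl group, gives a 2.5-fold lower number from compound 1 to compound 4 (0.40 log units; beyond the scatter). This position therefore accepts more than one halogen pattern, and the pattern itself shifts the number. In a physicochemical assay for lipophilicity, read by LC-MS, in phosphate buffer, measured as octanol-water partition, at pH 7.4 (a higher number here means a more lipophilic compound, a lower number a more polar compound), compound 2 gives 0.65 and compound 4 gives 1.1. In the physicochemical assay the same change from phenyl gives a modest rise: the measured distribution coefficient of compound 2, 0.65, and of compound 4, 1.1, a number 0.45 log units higher (beyond the scatter).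

The compounds shown do not separate the share of the chlorine from that of the two fluorines. As far as these compounds go, how a nitrile or an amine on this phenyl ring would read remains open.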